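The source may hold more compounds than are shown below. What is called first, only, known or untested is meant among the compounds shown, and "the series" means these compounds.

Measured compounds:
Compound 1, `CCc1nn(C)c(CO/N=C/c2c(C)nn(C)c2Oc2ccc(F)cc2)c1Cl`: in a functional assay on SMMC-7721 cells (Homo sapiens) for inhibition, read by MTT assay, with a stated time of 72 h, tested at 25 uM (a lower number here means less inhibition, a higher number more inhibition at the concentration tested (going by the name of the read-out)), compound 1 gives < 80%, which is a limit and not a number.
Compound 2, `CCc1nn(C)c(CO/N=C/c2c(C)nn(C)c2Oc2ccccc2F)c1Cl`: in this assay compound 2 gives < 80%, again a limit.
Compound 3, `Cc1nn(C)c(Oc2ccc(Cl)cc2)c1/C=N\OCc1c(Cl)c(-c2ccc(F)cc2)nn1C`: in this assay compound 3 gives 80%.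

Going by the values given here, compound 2 therefore stands only as a limit, and the one further value shown beside it, that of compound 1, is a limit as well; the limit of < 80% in this assay, at which 2 of the 3 values shown sit, marks where both sit. The step that the two limits leave unreadable from compound 1 to compound 2 is consequently unreadable, since both of its ends are limits. Among the compounds with values here, compound 3 carries the only plain number in the set, but no one-place step joins it to compound 2, so its value says nothing directly about the change studied here.

The unmeasured compound 4 is `CCc1nn(C)c(CO/N=C/c2c(C)nn(C)c2Oc2cccc(Cl)c2)c1Cl`. It differs from compound 2 by 3-chlorophenyl in place of 2-fluorophenyl on an oxygen on an aromatic ring. Within the data shown here, the only measured step that touches this position is the one from compound 1 to compound 2, and its size could not be read. With no readable step to lean on, no change beyond the scatter is expected in this assay in either direction, and compound 4 is expected to remain where compound 2 stands. Compound 4 is expected to give 45%, between 10% and 80%. The step from compound 2 to compound 4 is accordingly estimated at a step that the limit leaves unreadable from compound 2 to compound 4.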

Compound 4, a percentage reported as inhibition, at one concentration (the size of the read-out at that concentration, not a potency): < 80%
Compound 4 was reported as a limit; the forecaster's own chance of this, stated with the estimate: 70%; the middle value lies beyond the limit too.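

In this assay compound 4 gives < 80%, which is again a limit. No step among compound 1, compound 2 and compound 4 can be read, since both ends of each step are limits: the limit of < 80% in this assay, at which 3 of the 4 values shown sit.

The compounds shown leave open whether swapping 4-fluorophenyl, 2-fluorophenyl and 3-chlorophenyl on this oxygen changes the inhibition at all.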